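A few compounds are considered here, and "the series" means these few. Any claim that something is new, unique, unknown or untested is made for them only; others in the source may bear on it.

Among the compounds with values here, compound 3 `O=C(Nc1ccc(C(=O)O)nc1)c1ccc(Cl)cc1` stands second highest of the three numbers so far obtained in an assay on isolated protein (Gallus gallus) for inhibition of transmembrane prolyl 4-hydroxylase (Homo sapiens) (on this read-out lower numbers stand for stronger inhibition and higher numbers for weaker inhibition), where compound 3 gives 22500 nM. Its nearest neighbour is compound 2 `O=C(Nc1ccc(C(=O)O)nc1)c1ccccc1`, which in this assay gives 25600 nM, and its furthest is compound 1 `O=C(Nc1ccc(F)cc1)c1ccc(C(=O)O)nc1`, which in this assay gives 16100 nM; all three lie within the scatter of one another. Compound 4 `CCOc1ccc(C(=O)Nc2ccc(C(=O)O)nc2)cc1` has not yet been measured. It differs from compound 3 by ethoxy in place of chloro on an aromatic carbon. Within the data shown here, the only measured step that bears on this change is a 1.1-fold lower number from compound 2 to compound 3 (0.06 log units; within the scatter), likewise an exchange of the group on an aromatic carbon of the same ring, and it stayed within the scatter. On these data alone, on that basis no step beyond the scatter is expected in this assay in either direction, although the ethoxy group itself is untested, so the range is kept wide. Compound 4 is therefore estimated to give 20000 nM in this assay, with a range from 7000 nM to 60000 nM. The expected change is a 1.1-fold lower number from compound 3 to compound 4 (0.05 log units; within the scatter).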

Compound 4, half-maximal inhibitory concentration: 11200 nM
The estimate for compound 4 lay 1.8-fold (0.25 log units) above the measured number; the range from low to high includes it.
By their numbers in this assay, from the lowest: compounds 4, 1, 3 and 2 (each within the scatter of the next, the first and the last beyond it).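

In this assay, within the data shown here, ethoxy on this aromatic carbon, para to a large group, gives the first step to pass the scatter, with a 2.3-fold lower number from compound 2 to compound 4 (0.36 log units; beyond the scatter) against hydrogen, though the step is modest. Against chloro, the same group gives a 2.0-fold lower number from compound 3 to compound 4 (0.30 log units; within the scatter) and stays within the scatter, so ethoxy is not separated from chloro, just as chloro was not separated from hydrogen (a 1.1-fold lower number from compound 2 to compound 3 (0.06 log units; within the scatter)). Nothing available explains why ethoxy alone passes the scatter against hydrogen.

On these data alone, it remains open whether a shorter methoxy group or a longer propoxy chain would move the number further at this carbon, and whether an amine or a hydroxyl group would do the same. As far as these compounds go, it also remains open whether ethoxy in place of fluoro on the core of compound 1 would give a similar step.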